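Chain Lengthening in Two Series of Weak Methyltransferase Inhibitors

The source may hold more compounds than are shown below. What is called first, only, known or untested is meant among the compounds shown, and "the series" means these compounds.

Three compounds were measured in an assay on isolated protein for inhibition of Phenylethanolamine N-methyltransferase (Bos taurus); on this read-out lower numbers stand for stronger inhibition and higher numbers for weaker inhibition.
Compound 1 `CCCCC(O)CN` gave 345000 nM.
Compound 2 `CCCCCC(C#N)O[Si](C)(C)C` gave 314000 nM.
Compound 3 `CCCCCC(O)CN` gave 314000 nM.

Compound 3 stems from compound 1 by methyl in place of hydrogen on a saturated chain carbon, five bonds along the chain from an oxygen on a saturated carbon, a change that made a 1.1-fold lower number from compound 1 to compound 3 (0.04 log units; within the scatter). Compound 4 `CCCCCCC(C#N)O[Si](C)(C)C`, not yet measured, stems from compound 2 by methyl in place of hydrogen on a saturated chain carbon, six bonds along the chain from an oxygen on an unsaturated carbon and a triple-bonded carbon. The difference between the two cores, compound 1 and compound 2, is not broken down here. The two changes are the same kind of change, not the same: in compound 1 the place is five bonds along the chain from an oxygen on a saturated carbon, in compound 2 it is six bonds along the chain from an oxygen on an unsaturated carbon and a triple-bonded carbon. Compound 2 and compound 3 stand level at the digits given. Because a 1.1-fold lower number from compound 1 to compound 3 (0.04 log units; within the scatter) stayed within the scatter, the step in this assay is expected to be a 1.1-fold lower number from compound 2 to compound 4 (0.03 log units; within the scatter). Compound 4 is estimated at 290000 nM, between 150000 nM and 600000 nM.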

Compound 4, half-maximal inhibitory concentration: 109000 nM
For compound 4 the middle estimate is 2.7-fold (0.42 log units) above the measured one; the measured number lies below the stated range.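

In this assay methyl in place of hydrogen on the core of compound 2 gave a 2.9-fold lower number from compound 2 to compound 4 (0.46 log units; beyond the scatter) on a saturated chain carbon. Set beside the same kind of change on the core of compound 1, the two steps cannot be told apart: the same change on two cores in this assay, a 1.1-fold lower number (0.04 log units; within the scatter) from compound 1 to compound 3 and a 2.9-fold lower number (0.46 log units; beyond the scatter) from compound 2 to compound 4, 2.6-fold (0.42 log units) apart, within the scatter of two such steps. Among the compounds shown here, this shows no measured difference in how the change carries from one core to the other, but it does not show that the change carries over equally, for the place differs between the two cores and each core offers only one pair.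

On these data alone, whether a longer chain would lower the number further on either core stays open. So does whether a carboxylic acid in place of the nitrile would keep the number of compound 4.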